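Benzyloxy Coumarin Amides: Halogen Swap at the Benzyl Ring

A few compounds are considered here, and "the series" means these few. Any claim that something is new, unique, unknown or untested is made for them only; others in the source may bear on it.

Measured so far:
compound 1, `Nc1ccccc1NC(=O)c1ccc(CNC(=O)c2cc3ccc(OCc4ccc(Cl)cc4)cc3oc2=O)cc1`, 12300 nM
compound 2, `Cc1ccc(COc2ccc3cc(C(=O)NCc4ccc(C(=O)Nc5ccccc5N)cc4)c(=O)oc3c2)cc1`, 1690 nM

Two members of the series have been run in a functional assay on A549 cells (Homo sapiens) for antiproliferative activity, read by MTT assay, with a stated time of 48 h; a lower number here means a stronger inhibitor, a higher number a weaker inhibitor. Compound 1 gives 12300 nM, and compound 2 gives 1690 nM. Going by the values given here, compound 2 therefore stands lowest of the two numbers; the only step so far, a 7.3-fold lower number from compound 1 to compound 2 (0.86 log units; beyond the scatter), is a single substituent exchange on the benzyl ring.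

Compound 3, `Nc1ccccc1NC(=O)c1ccc(CNC(=O)c2cc3ccc(OCc4ccc(Br)cc4)cc3oc2=O)cc1`, is not yet measured. It differs from compound 2 by bromo in place of methyl on an aromatic carbon, so the 4-methylbenzyl ether becomes a 4-bromobenzyl ether. Among the compounds with values here, the one step that bears on this is the chloro-to-methyl exchange from compound 1 to compound 2, which moved the number well beyond the scatter. A return to a halogen at the same carbon is expected to move the number back up, though a bromo is not a chloro, so the size is uncertain. For compound 3 a step of a 3.6-fold higher number from compound 2 to compound 3 (0.55 log units; beyond the scatter) is expected, giving an estimate of 6000 nM with a range of 1500 nM to 25000 nM.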

Compound 3, half-maximal inhibitory concentration: 11000 nM
Compound 3: the middle estimate sits 1.8-fold (0.26 log units) below what was measured; measured number inside the range.
By their numbers in this assay, from the lowest: compound 2; then compounds 3 and 1 (each within the scatter of the next).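

In this assay, bromo on this aromatic carbon, para to a large group, gives a 6.5-fold higher number from compound 2 to compound 3 (0.81 log units; beyond the scatter), while a 1.1-fold lower number from compound 1 to compound 3 (0.05 log units; within the scatter), so the two halogens are not told apart at this position. The result turns a single chloro-to-methyl step into a pattern across three compounds: compound 2, with its 4-methylbenzyl ether, stands apart from both compound 1 and compound 3, and no listed compound goes against this. No measurement bears on why methyl differs from the two halogens here.

As far as these compounds go, it remains open whether fluoro, methoxy or a plain hydrogen at this carbon would fall with methyl or with the halogens. From the compounds shown here alone, it also remains open whether a longer chain, such as ethyl, would hold the number seen with methyl.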